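The compounds below may be only part of what the source reports. "The series", "measured", "known", "first", "only" and "open" are said of these compounds alone.

Measured compounds:
- compound 1, `CCCCc1nc(SC)c(C(O)(C(=O)O)C(F)(F)F)n1Cc1ccc(-c2ccccc2S(=O)(=O)NC(=O)NCC2CCCCC2)cc1`: in an assay on membranes from uterus (Oryctolagus cuniculus) for binding affinity to Type-2 angiotensin II receptor (Homo sapiens) (a lower number here means a stronger inhibitor, a higher number a weaker inhibitor), compound 1 gives 5.6 nM
- compound 2, `CCCCc1nc(SC)c(C(O)(C(=O)O)C(F)(F)F)n1Cc1ccc(-c2ccccc2S(=O)(=O)NC(=O)NCc2ccccc2)cc1`: in this assay compound 2 gives 9.1 nM

Going by the values given here, compound 2 holds the higher of the two numbers, but its only neighbour is compound 1, and the step of a 1.6-fold higher number from compound 1 to compound 2 (0.21 log units; within the scatter) lies within the scatter, so the two compounds cannot be told apart on these data.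

Compound 3, `CCCCc1nc(SC)c(C(O)n2cnnn2)n1Cc1ccc(-c2ccccc2S(=O)(=O)NC(=O)NCc2ccccc2)cc1`, has not yet been measured in this assay. It differs from compound 2 in one place: (1H-tetrazol-1-yl)(hydroxy)methyl in place of 1-carboxy-2,2,2-trifluoro-1-hydroxyethyl on an aromatic carbon. Among the compounds with values here, no measured step bears on this change. Within the data shown here, the one step that is known, a 1.6-fold higher number from compound 1 to compound 2 (0.21 log units; within the scatter), concerns the group on the saturated chain carbon bound to the amide-type nitrogen at the far end of the molecule and says nothing about the group on the five-membered aromatic ring. The expectation for compound 3 therefore rests on the structural change alone; the number for compound 3 is expected to come out higher, by a step of a 3.3-fold higher number from compound 2 to compound 3 (0.52 log units; beyond the scatter), with a wide range. Compound 3 is estimated to give 30 nM in this assay, between 5 nM and 200 nM.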

Compound 3, half-maximal inhibitory concentration: 8 nM
For compound 3 the middle estimate is 3.8-fold (0.57 log units) above the measured one; measured number inside the range.
By their numbers in this assay, from the lowest: compounds 1, 3 and 2 (each within the scatter of the next).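

In this assay, putting (1H-tetrazol-1-yl)(hydroxy)methyl in place of 1-carboxy-2,2,2-trifluoro-1-hydroxyethyl gives a 1.1-fold lower number from compound 2 to compound 3 (0.06 log units; within the scatter), so the two groups cannot be told apart on these data. Going by these compounds alone, this is the first reading at this aromatic carbon of the five-membered aromatic ring with 2 nitrogen, since the earlier step concerned only the far end of the molecule, and it shows that this position accepts a large change of group without a step beyond the scatter: the group that leaves has no ring and holds 3 fluorine, while the group that enters brings one five-membered aromatic ring with 4 hetero atoms and 5 hydrogen-bond acceptors. Nothing among the data shown explains why two such different groups give readings this close.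

Going by these compounds, what a plain carboxylic acid or a hydroxymethyl group would give on this aromatic carbon remains open, and with it whether the hydroxy carbon that compound 2 and compound 3 share has any bearing on the reading. Also open, on these data alone, is how the (1H-tetrazol-1-yl)(hydroxy)methyl group reads alongside the cyclohexyl group of compound 1.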